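The compounds below may be only part of what the source reports. "The series", "measured", "known", "first", "only" and "open" are said of these compounds alone.

Among the measured compounds shown here, compound 2, `COc1ccc(Nc2cc3[nH]c(-c4cccc(C(F)(F)F)c4)nc3cn2)nc1`, is one of two compounds measured here in a physicochemical assay for solubility, using the shake flask method, in phosphate buffer, measured as kinetic solubility, with a stated time of 20 h, at pH 6.5; a higher number here means a more soluble compound, a lower number a less soluble compound. Compound 2 gives a value that is a limit of the assay rather than a number, < 5000 nM. For the measured compounds named here, the only other compound measured, compound 1, `FC(F)(F)Oc1ccc(-c2nc3cnc(Nc4ccccn4)cc3[nH]2)cc1`, likewise gives a limit, < 5000 nM, so the two values cannot be placed in any order relative to each other; both sit at the same edge of the assay, which is the state described by the limit of < 5000 nM in this assay, at which 2 of the 2 values shown sit.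

Compound 3, `N#Cc1ccc(Nc2cc3[nH]c(-c4cccc(C(F)(F)F)c4)nc3cn2)nc1`, has not been measured in this assay. It differs from compound 2 in one place: cyano in place of methoxy on an aromatic carbon of a six-membered aromatic ring with one nitrogen, two atoms from the ring nitrogen, para to a large group. Going by the values given here, no measured pair shows what such a change does in this assay, so the size of the step from compound 2 to compound 3 can only be anticipated as an estimate, a step that the limit leaves unreadable from compound 2 to compound 3, with no direction resolvable beyond the scatter. Compound 3 is expected to give about 3000 nM, within 500 nM to 7000 nM, and most probably again only a limit.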

Compound 3, solubility: < 5000 nM
Compound 3 ended at the assay's limit; the forecaster's own chance of this, stated with the estimate: 80%; the middle value lies beyond the limit too.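

In this assay compound 3 gives < 5000 nM, a limit and not a number. Among the compounds shown here, compound 2 also gives a limit, so no step between compound 2 and compound 3 can be read. The compounds shown leave open what cyano in place of methoxy does in this assay, and how far each compound lies from the edge they share: the limit of < 5000 nM in this assay, at which 3 of the 3 values shown sit.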